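A spiro core with a triazolylmethyl group: three limits

The source may report more compounds than this note shows. Statements on the series, on what has been measured and on what is new or still open speak of the compounds shown alone.

Compound 1, with the structure `N#CC1=C(N)Oc2c(c3nc4ccccc4nc3c3ccccc23)C12C(=O)N(Cc1cnnn1-c1cccc(Cl)c1)c1ccccc12`, and compound 2, with the structure `N#CC1=C(N)Oc2c(c3nc4ccccc4nc3c3ccccc23)C12C(=O)N(Cc1cnnn1-c1ccc(F)c(Cl)c1)c1ccccc12`, share a spiro core that carries a triazolylmethyl arm on the amide nitrogen. In an ADME assay on HUVEC cells (Homo sapiens) for antiproliferative activity, read by MTT assay, with a stated time of 48 h (on this read-out lower numbers stand for stronger inhibition and higher numbers for weaker inhibition), compound 1 gives only a limit of the assay, > 50000 nM. In this assay compound 2 likewise gives only a limit, > 50000 nM. The step that the two limits leave unreadable from compound 1 to compound 2 therefore cannot be read. Compound 3, with the structure `CC(=O)Nc1ccc(-n2nncc2CN2C(=O)C3(C(C#N)=C(N)Oc4c(N)cc5nc6ccccc6nc5c43)c3ccccc32)cc1`, differs from these two in the amino group on its core and in the aryl group on the triazole. In this assay compound 3 also gives only a limit, > 50000 nM, so its standing among the numbers shown is that of a limit, not of a value, because the limit of > 50000 nM in this assay, at which 3 of the 3 values shown sit, holds for every compound shown.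

Compound 4, with the structure `Cc1ccc(Cl)cc1-n1nncc1CN1C(=O)C2(C(C#N)=C(N)Oc3c(N)cc4nc5ccccc5nc4c32)c2ccccc21`, is reached from compound 3 by the change (5-chloro-2-methylphenyl in place of 4-acetamidophenyl on an aromatic nitrogen). No measured step bears on this change: the only step shown is unreadable, and all three values sit at the same limit. On that basis compound 4 is expected to give 60000 nM, with a range from 15000 nM to 300000 nM. The estimated step that the limit leaves unreadable from compound 3 to compound 4 is expected to stay within the scatter, most likely as a further limit.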

Compound 4, half-maximal inhibitory concentration: > 50000 nM
Compound 4 was reported as a limit (the forecaster's own chance of this, stated with the estimate: 80%); the middle value lies beyond the limit too.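

In this assay compound 4 gives only a limit, > 50000 nM. The step from compound 3 to compound 4 therefore cannot be read, because every compound shown sits at the same limit: the limit of > 50000 nM in this assay, at which 4 of the 4 values shown sit.

The compounds shown leave open whether any of these changes alters antiproliferative activity at all.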